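The source may hold more compounds than are shown below. What is called first, only, known or untested is meant among the compounds shown, and "the series" means these compounds.

Compound 1, `c1cc(OCc2ccc3ccccc3n2)cc(-c2nn[nH]n2)c1`: 115 nM
Compound 2, `c1cc(OCc2ccc3ccccc3n2)cc(OCc2nn[nH]n2)c1`: 85 nM
Compound 3, `c1cc(OCCCCc2nnn[nH]2)cc(OCc2ccc3ccccc3n2)c1`: 75 nM

In an assay on isolated protein for binding affinity to cysteinyl leukotriene receptor 1 (Cavia porcellus) (on this read-out higher numbers stand for weaker inhibition and lower numbers for stronger inhibition), compound 3 stands at the lower end of the three numbers, yet compound 2 and compound 1 both lie within the usual scatter of it, so none of the three can be called stronger or weaker than the others. The two measured steps each shift the tetrazole group outward along a chain: a 1.4-fold lower number from compound 1 to compound 2 (0.13 log units; within the scatter) and a 1.1-fold lower number from compound 2 to compound 3 (0.05 log units; within the scatter). Both are within the scatter, which suggests that moving the tetrazole group about on this side of the shared core changes little.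

Compound 4, `CCOC(=O)CCCOc1cccc(OCc2ccc3ccccc3n2)c1`, takes a different kind of step: ethoxycarbonyl in place of (1H-tetrazol-5-yl)methyl on a saturated chain carbon, three bonds along the chain from an oxygen on an aromatic ring. Here the tetrazole ring is not moved but removed, and an ester group takes its place. Going by the values given here, no measured step covers such a swap, so the two steps above give only indirect guidance, and the expectation must carry a wide range. The estimate is a rise in the number, a 5.3-fold higher number from compound 3 to compound 4 (0.73 log units; beyond the scatter), placing compound 4 at an expected 400 nM, somewhere between 100 nM and 2500 nM.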

Compound 4, inhibition constant: 160 nM
Beside the measured number, compound 4's estimate is 2.5-fold (0.40 log units) above it; the measured number falls inside the stated range.
By their numbers in this assay, from the lowest: compounds 3, 2, 1 and 4 (each within the scatter of the next, the first and the last beyond it).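

Swapping the tetrazole ring at the end of the chain for ethoxycarbonyl, a group with no ring and no hydrogen-bond donor, gives a 2.1-fold higher number from compound 3 to compound 4 (0.33 log units; beyond the scatter) in this assay, and unlike the steps that only shifted the tetrazole, this one passes the usual scatter. The ester is still not clearly separated from the two compounds with shorter tetrazole side chains, since both a 1.9-fold higher number from compound 2 to compound 4 (0.27 log units; within the scatter) and a 1.4-fold higher number from compound 1 to compound 4 (0.14 log units; within the scatter) stay within the scatter. So at this chain end, the tetrazole ring can be lost at only a modest cost in this read-out, although nothing measured here explains the size of that cost.

On these data alone, it remains open whether a carboxylic acid or a primary amide at the end of the same chain would read like compound 3 or like compound 4. Also open, as far as these compounds go, is whether ethoxycarbonyl on a shorter or longer chain would give a step of the same size.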